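An Isopropyl Group on the Phenyl Ring of Compound 1

The source may hold more compounds than are shown below. What is called first, only, known or untested is meant among the compounds shown, and "the series" means these compounds.

Of the compounds shown here, three sharing one core have been tested in an ADME assay on cells (Splenocyte, Mus musculus, strain BALB/c) for cytotoxicity, read by thymidine incorporation, with a stated time of 24 h; on this read-out lower numbers stand for stronger inhibition and higher numbers for weaker inhibition. Compound 1 `O=C(CCN1CCN(c2ccnc3cc(Cl)ccc23)CC1)N/N=C/c1ccccc1` carries a plain phenyl on the carbon with a double bond to nitrogen and gives 300 nM, the lowest number of the three. Compound 2 `COc1cc(/C=N/NC(=O)CCN2CCN(c3ccnc4cc(Cl)ccc34)CC2)ccc1O`, with a 4-hydroxy-3-methoxyphenyl in that place, gives 9400 nM, and compound 3 `O=C(CCN1CCN(c2ccnc3cc(Cl)ccc23)CC1)N/N=C/c1ccccc1Cl`, with a 2-chlorophenyl, gives 10800 nM. Both changes to the phenyl made the number climb steeply: a 31-fold higher number from compound 1 to compound 2 (1.50 log units; beyond the scatter) and a 36-fold higher number from compound 1 to compound 3 (1.56 log units; beyond the scatter), while a 1.1-fold higher number from compound 2 to compound 3 (0.06 log units; within the scatter), so the two substituted rings cannot be told apart on these numbers.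

Compound 4 `CC(C)c1ccc(/C=N/NC(=O)CCN2CCN(c3ccnc4cc(Cl)ccc34)CC2)cc1` has not yet been measured. It differs from compound 1 in a single spot: isopropyl in place of hydrogen on an aromatic carbon. The isopropyl sits para to a large group, a position not probed by compound 2 or compound 3, so neither measured step matches this change exactly. For the measured compounds named here, the only guidance is that every decoration of this ring so far has weakened compound 1 by a large margin. A sizeable rise is therefore expected, a 10-fold higher number from compound 1 to compound 4 (1.00 log units; beyond the scatter), though a smaller shift than the measured ones remains possible. The estimate for compound 4 in this assay is 3000 nM, with a range from 500 nM to 15000 nM.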

Compound 4, half-maximal inhibitory concentration: 7900 nM
Estimate against measurement, compound 4: 2.6-fold (0.42 log units) below; low and high end bracket the measured number.
By their numbers in this assay, from the lowest: compound 1; then compounds 4, 2 and 3 (each within the scatter of the next).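

In this assay, an isopropyl, which adds only carbon and no hydrogen-bond donors or acceptors, is enough on this aromatic carbon para to a large group to give a 26-fold higher number from compound 1 to compound 4 (1.42 log units; beyond the scatter), so a large rise does not require the oxygen atoms of compound 2 or the chlorine of compound 3. The new ring also falls in with the other two substituted rings, with a 1.4-fold lower number from compound 3 to compound 4 (0.14 log units; within the scatter) and a 1.2-fold lower number from compound 2 to compound 4 (0.08 log units; within the scatter), so all three stay indistinguishable while compound 1, with its plain phenyl, keeps the lowest number of the four. No evidence here explains the gap between the plain phenyl and the three substituted rings.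

As far as these compounds go, compounds 3 and 4 differ in both the group and where it sits, so the effect of place alone stays open, and a chloro on the carbon that holds the isopropyl in compound 4 would help separate the two. Also open, from the compounds shown here alone, is whether a methyl, an amine or a carboxylic acid on that same carbon would bring the number back toward that of compound 1 or leave it with the other substituted rings.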